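Allyl in place of methyl on the shared core

A few compounds are considered here, and "the series" means these few. Any claim that something is new, unique, unknown or untested is made for them only; others in the source may bear on it.

compound 1 `COC(=O)c1ccc([N+](=O)[O-])c(-c2nc3ccccc3n(Cc3ccccc3)c2=O)c1`: 9900 nM
compound 2 `O=c1c(-c2ccccc2)nc2ccccc2n1Cc1ccccc1`: 5000 nM
compound 3 `Cn1c(=O)c(-c2cccc([N+](=O)[O-])c2)nc2ccccc21`: > 10000 nM

In an assay on cells for activation of Cystic fibrosis transmembrane conductance regulator (Homo sapiens), read by fluorescence, with a stated time of 10 min (a lower number here means that less compound is needed, a higher number that more compound is needed for the effect), compound 1 gives 9900 nM and compound 2 gives 5000 nM. Compound 3 is recorded only as a limit, > 10000 nM; this is the limit of > 10000 nM in this assay, at which 1 of the 3 values shown sits. Compound 4 `C=CCn1c(=O)c(-c2cccc([N+](=O)[O-])c2)nc2ccccc21` differs from compound 3 by vinyl in place of hydrogen on a saturated chain carbon bound to an aromatic nitrogen. For the measured compounds named here, no measured pair differs in this one place, so the size of the step is open. Compound 2 at 5000 nM and compound 1 at 9900 nM show that compounds carrying a larger group in that same place return numbers. A step from compound 3 to compound 4 of an at least 1.2-fold lower number from compound 3 to compound 4 (0.09 log units; that floor lies within the scatter) toward a lower number is expected, modest and possibly inside the scatter. Compound 4 is estimated at 8000 nM, range 3000 nM to 25000 nM, with a real chance of another limit.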

Compound 4, half-maximal effective concentration: 55 nM
Estimate against measurement, compound 4: 150-fold (2.16 log units) above; measured number outside the range, below it.
By their numbers in this assay, from the lowest: compound 4; then compounds 2 and 1 (each within the scatter of the next). At a limit, above all of these: compound 3.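

In this assay, the place on a saturated chain carbon bound to an aromatic nitrogen proves highly sensitive: going from methyl to allyl gives an at least 180-fold lower number from compound 3 to compound 4 (2.25 log units; beyond the scatter). The entering vinyl adds only 2 heavy atoms, with no ring and no net charge, yet the step lies beyond the scatter. The size of the step is a floor, since compound 3 is recorded only as a limit: the limit of > 10000 nM in this assay, at which 1 of the 4 values shown sits.

A saturated propyl chain in this place would show whether the double bond matters or only the chain length. Going by these compounds, whether allyl gives the same step with other aryl groups on the shared core stays open.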